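T-type channel series: aryl swap on the piperazine nitrogen

The source may report more compounds than this note shows. Statements on the series, on what has been measured and on what is new or still open speak of the compounds shown alone.

Measured compounds:
- compound 1 `CCCc1nc(-c2ccccc2)c(CNCCCN2CCN(c3ccc(F)cc3)CC2)o1`: 3210 nM
- compound 2 `CCCc1nc(-c2ccccc2)c(CNCCN2CCN(c3ccccc3C)CC2)o1`: 4300 nM
- compound 3 `CCCc1nc(-c2ccccc2)c(CNCCN2CCN(c3cccc(Cl)c3)CC2)o1`: 1450 nM

All three share one core and differ in the chain and in the aryl group on the amine nitrogen in the ring. In an assay on HEK293 cells for inhibition of Voltage-dependent T-type calcium channel subunit alpha-1G (Homo sapiens), read by patch clamp (on this read-out higher numbers stand for weaker inhibition and lower numbers for stronger inhibition), compound 1 gives 3210 nM, the second highest of the three numbers; the gap to compound 2 lies within the scatter, while compound 3 sits at 1450 nM, a gap beyond the scatter.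

Compound 4 `CCCc1nc(-c2ccccc2)c(CNCCCN2CCN(c3cccc(Cl)c3)CC2)o1` is not yet measured. It is compound 1 with 3-chlorophenyl in place of 4-fluorophenyl on an amine nitrogen in a ring.

Within the data shown here, the only measured step that bears on this change is a 3.0-fold lower number from compound 2 to compound 3 (0.47 log units; beyond the scatter), where a 3-chlorophenyl likewise enters in place of another aryl group on the same ring nitrogen, though starting from 2-methylphenyl rather than 4-fluorophenyl and on a shorter chain. Compound 1 and compound 2 lie within scatter of each other, so the starting points are comparable. Among the measured compounds shown here, a step of similar direction is therefore expected for compound 4, with a lower number in this assay, but of uncertain size, since no direct step from 4-fluorophenyl to 3-chlorophenyl has been measured.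

Compound 4 is estimated at 1500 nM in this assay, with a range of 700 nM to 3500 nM, meaning an expected step of a 2.1-fold lower number from compound 1 to compound 4 (0.33 log units; beyond the scatter).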

Compound 4, half-maximal inhibitory concentration: 1750 nM
Compound 4: the middle estimate sits 1.2-fold (0.07 log units) below what was measured; the measured number falls inside the stated range.
By their numbers in this assay, from the lowest: compounds 3, 4, 1 and 2 (each within the scatter of the next, the first and the last beyond it).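

In this assay, the direct exchange of 4-fluorophenyl for 3-chlorophenyl on an amine nitrogen in a ring gives a 1.8-fold lower number from compound 1 to compound 4 (0.26 log units; within the scatter), so on this chain the two aryl groups cannot be told apart. The earlier exchange, a 3.0-fold lower number from compound 2 to compound 3 (0.47 log units; beyond the scatter), lies beyond the scatter, but it starts from 2-methylphenyl on the other chain, so that step alone does not establish a general advantage for 3-chlorophenyl at this position. Among these compounds, compound 4 also gives the first pair with the same 3-chlorophenyl on both chains: compound 3 reads 1450 nM and compound 4 reads 1750 nM, within the scatter of each other, so these two compounds show no separation by chain length.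

No available evidence accounts for any of these values or steps. Still open, from the compounds shown here alone, is how a 4-chlorophenyl, a 3-fluorophenyl or an unsubstituted phenyl on the same ring nitrogen would read on either chain, which would help separate the identity of the halogen from its place on the aryl ring.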